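A few compounds are considered here, and "the series" means these few. Any claim that something is new, unique, unknown or untested is made for them only; others in the source may bear on it.

Measured compounds in the series:
- compound 1 `Cn1c(=O)c(=O)n(C2CCCC2)c2nc(N/N=C/c3ccc(C(F)(F)F)cc3)ncc21`, 40600 nM
- compound 2 `Cn1c(=O)c(=O)n(C2CCCC2)c2nc(N/N=C/c3cccc(Cl)c3Cl)ncc21`, 39100 nM
- compound 3 `Cn1c(=O)c(=O)n(C2CCCC2)c2nc(N/N=C/c3cccc([N+](=O)[O-])c3)ncc21`, 12300 nM

In a functional assay on A549 cells (Homo sapiens) for antiproliferative activity, read by MTT assay (a lower number here means a stronger inhibitor, a higher number a weaker inhibitor), compound 2 stands second highest of the three numbers. Its nearest neighbour is compound 1: a 1.0-fold lower number from compound 1 to compound 2 (0.02 log units; within the scatter). Its furthest is compound 3: a 3.2-fold lower number from compound 2 to compound 3 (0.50 log units; beyond the scatter). Within the data shown here, compound 1 and compound 3 also differ, a 3.3-fold lower number from compound 1 to compound 3 (0.52 log units; beyond the scatter), so the only step beyond the scatter among the three is the one that brings in the 3-nitrophenyl group.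

The unmeasured compound 4 `CSc1ccc(/C=N/Nc2ncc3c(n2)n(C2CCCC2)c(=O)c(=O)n3C)cc1` differs from compound 2 in one place: 4-(methylsulfanyl)phenyl in place of 2,3-dichlorophenyl on a carbon with a double bond to nitrogen

Among the measured compounds shown here, no measured step brings in a 4-(methylsulfanyl)phenyl group, so the change has no direct precedent here. The two steps that bear on it are those exchanging the aryl group on the same carbon: from compound 1 to compound 2 nothing beyond the scatter, and from compound 2 to compound 3 a modest lowering. Exchanging one aryl group lacking a nitro substituent for another has so far given no change beyond the scatter; the 3-nitrophenyl case is the exception. The expectation for compound 4 is therefore a step within the scatter, perhaps slightly lower, a 1.3-fold lower number from compound 2 to compound 4 (0.12 log units; within the scatter). Compound 4 is estimated at 30000 nM, with a range from 12000 nM to 80000 nM.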

Compound 4, half-maximal inhibitory concentration: 14100 nM
Beside the measured number, compound 4's estimate is 2.1-fold (0.33 log units) above it; low and high end bracket the measured number.
By their numbers in this assay, from the lowest: compounds 3 and 4 (each within the scatter of the next); then compounds 2 and 1 (each within the scatter of the next).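

In this assay, among these compounds, the 4-(methylsulfanyl)phenyl group gives a 2.8-fold lower number from compound 2 to compound 4 (0.44 log units; beyond the scatter) on this carbon with a double bond to nitrogen, so 3-nitrophenyl is no longer the only aryl group here that separates from 2,3-dichlorophenyl beyond the scatter. The step of a 2.9-fold lower number from compound 1 to compound 4 (0.46 log units; beyond the scatter) is a cleaner comparison than the earlier aryl exchanges, since methylsulfanyl replaces trifluoromethyl on an aromatic carbon and the rest of the aryl group stays the same, while a 1.1-fold higher number from compound 3 to compound 4 (0.06 log units; within the scatter) shows that two quite different aryl groups cannot be told apart in this assay. Nothing on hand accounts for these differences among the aryl groups.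

The compounds shown leave open whether the sulfur atom matters for the lower number, which a 4-methoxyphenyl or 4-methylphenyl group on the same carbon would test. They also leave open how far the placement of a group counts, since 4-nitrophenyl and 3-(methylsulfanyl)phenyl do not appear among them, and whether an amine or a carboxylic acid on the aryl ring would fit the same picture.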